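The source may hold more compounds than are shown below. What is called first, only, known or untested is meant among the compounds shown, and "the series" means these compounds.

Measured compounds in a functional assay on HeLa cells (Homo sapiens) for inhibition, read by sulforhodamine B assay; on this read-out lower numbers stand for stronger inhibition and higher numbers for weaker inhibition:
compound 1, `COc1cccc(NC2=CC(=O)c3c(nc4n3[C@H]3OC[C@@H](O)[C@H]3OC4)C2=O)c1`: > 8000 nM
compound 2, `O=C1C(NCc2ccccc2)=CC(=O)c2c1nc1n2[C@H]2OC[C@@H](O)[C@H]2OC1`: 11000 nM

For the measured compounds named here, compound 2, built on the shared core with a benzyl group on the amine nitrogen, is the one compound of the pair that gives an actual number in this assay, namely 11000 nM. For compound 1 the value is a limit of the assay, > 8000 nM, and not a number. The step that the limit leaves unreadable from compound 1 to compound 2 therefore cannot be read, as the limit of > 8000 nM in this assay, at which 1 of the 2 values shown sits, makes plain.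

Compound 3, `O=C1C(Nc2cccc(Cl)c2)=CC(=O)c2c1nc1n2[C@H]2OC[C@@H](O)[C@H]2OC1`, differs from compound 2 in one place: 3-chlorophenyl in place of benzyl on an amine nitrogen. Compound 1 also carries an aryl group on that nitrogen, so compound 3 stands structurally between the two measured compounds, but no readable step connects them. What the data allow is this: compound 2 gives a weak number, and compound 1 gives only a limit. The expected step of a 1.1-fold higher number from compound 2 to compound 3 (0.04 log units; within the scatter) is therefore set at no change beyond the scatter, with a wide band and a real chance that compound 3 returns only a limit. Compound 3 is estimated at 12000 nM, between 4000 nM and 40000 nM.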

Compound 3, half-maximal inhibitory concentration: 7970 nM
Estimate against measurement, compound 3: 1.5-fold (0.18 log units) above; the range from low to high includes it.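

In this assay, for the compounds shown here, the exchange of benzyl for 3-chlorophenyl on the amine nitrogen gives the first readable step at this position, a 1.4-fold lower number from compound 2 to compound 3 (0.14 log units; within the scatter), so in this pair the two groups cannot be told apart in this assay. The value of compound 1, > 8000 nM, is a limit of the assay and not a number. The step of a number no higher from compound 1 to compound 3 (the limit leaves the size open) therefore gives no size for the change to chloro in place of methoxy on the aromatic carbon: the limit of > 8000 nM in this assay, at which 1 of the 3 values shown sits.

The compounds shown leave open whether any group on this nitrogen can move the number beyond the scatter, since the one readable step at this position stays within it. A longer chain in place of benzyl, or an amine or a carboxylic acid on the aromatic ring, could show whether this nitrogen tolerates more than the groups seen here.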